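From Dimethylamino to Piperidinyl on the Aminomethyl Chain

The compounds below may be only part of what the source reports. "The series", "measured", "known", "first", "only" and "open" are said of these compounds alone.

Compound 1 `CCN(CC)CN1C(=O)/C(=N\c2nc3ccc(C)cc3s2)c2c(Br)cccc21`: 30200 nM
Compound 2 `Cc1ccc2nc(/N=C3\C(=O)N(CN(C)C)c4cccc(Br)c43)sc2c1`: 18000 nM

In a functional assay on MCF7 cells (Homo sapiens) for cytotoxicity, read by sulforhodamine B assay, with a stated time of 48 h (a higher number here means a weaker inhibitor of growth, a lower number a stronger inhibitor of growth), compound 2 gives the lowest of the two numbers, with compound 1 nearest at a 1.7-fold lower number from compound 1 to compound 2 (0.22 log units; within the scatter). Compound 3 `Cc1ccc2nc(/N=C3\C(=O)N(CN4CCCCC4)c4cccc(Br)c43)sc2c1` carries piperidin-1-yl in place of dimethylamino on a saturated chain carbon bound to an amide-type nitrogen in a ring. Going by the values given here, the only step that bears on this change is the one from compound 1 to compound 2, which lies within the scatter, so no step beyond the scatter is expected in this assay for compound 3. Compound 3 is therefore estimated at 15000 nM with a range of 6000 nM to 40000 nM, an expected step of a 1.2-fold lower number from compound 2 to compound 3 (0.08 log units; within the scatter).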

Compound 3, concentration for 50% growth inhibition: 39100 nM
Estimate against measurement, compound 3: 2.6-fold (0.42 log units) below; the measured number falls inside the stated range.
By their numbers in this assay, from the lowest: compounds 2, 1 and 3 (each within the scatter of the next, the first and the last beyond it).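

In this assay, going by these compounds alone, piperidin-1-yl in place of dimethylamino on a saturated chain carbon bound to an amide-type nitrogen in a ring gives a 2.2-fold higher number from compound 2 to compound 3 (0.34 log units; beyond the scatter) and is the first change at this place to pass the scatter, though only modestly. Against diethylamino the same group gives a 1.3-fold higher number from compound 1 to compound 3 (0.11 log units; within the scatter) and no real separation, so the shift is seen only against dimethylamino. Nothing available explains this difference. The compounds shown leave open whether morpholin-4-yl or pyrrolidin-1-yl at this place would read like piperidin-1-yl or like dimethylamino.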